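Moving the chlorine on the urea phenyl ring

The compounds below may be only part of what the source reports. "The series", "measured", "known", "first", "only" and "open" are said of these compounds alone.

Two ureas sharing the same core have been measured in an assay on isolated protein for inhibition of Polyunsaturated fatty acid 5-lipoxygenase (Homo sapiens), read by HPLC, with a stated time of 10 min; on this read-out higher numbers stand for weaker inhibition and lower numbers for stronger inhibition. Compound 1 `Cc1cc(NC(=O)Nc2ccc(Cl)c(Cl)c2)ccc1OCc1nc2ccccc2s1` gives 2170 nM, and compound 2 `Cc1cc(NC(=O)Nc2ccccc2Cl)ccc1OCc1nc2ccccc2s1` gives 680 nM. For the measured compounds named here, compound 2 therefore holds the lowest of the two numbers, with compound 1 as its only neighbour, separated by the step of a 3.2-fold lower number from compound 1 to compound 2 (0.50 log units; beyond the scatter). Compound 3 `Cc1cc(NC(=O)Nc2ccc(Cl)cc2)ccc1OCc1nc2ccccc2s1` has not yet been measured; it differs from compound 2 only in that (4-chlorophenyl in place of 2-chlorophenyl on an amide-type nitrogen). Going by the values given here, the single measured step bears on this change only indirectly, since it swaps 3,4-dichlorophenyl for 2-chlorophenyl, and compound 3 carries one chlorine in a position shared with neither. A modest rise in the number is expected, with compound 3 estimated at 1200 nM (range 450 nM to 3200 nM), that is an expected step of a 1.8-fold higher number from compound 2 to compound 3 (0.25 log units; within the scatter).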

Compound 3, half-maximal inhibitory concentration: > 10000 nM
Compound 3 gave a limit, no number; the forecaster's own chance of this, stated with the estimate: 5%; middle value at least 8.3-fold (0.92 log units) from the limit.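

In this assay compound 3 gives only a limit, not a number: the limit of > 10000 nM in this assay, at which 1 of the 3 values shown sits. With the same atoms joined differently, 4-chlorophenyl in place of 2-chlorophenyl on the amide-type nitrogen is a large change, an at least 14-fold higher number from compound 2 to compound 3 (1.16 log units; beyond the scatter), so among these ureas it is the place of the single chlorine on this ring that counts, not just its presence. Hydrogen in place of chloro on an aromatic carbon also weakens inhibition, an at least 4.6-fold higher number from compound 1 to compound 3 (0.66 log units; beyond the scatter), so the 3,4-dichlorophenyl ring retains inhibition that the 4-chlorophenyl ring falls short of.

On these data alone, how far compound 3 lies past its limit remains open, and with it the full size of both steps. Also open, as far as these compounds go, is whether a fluoro or methoxy group in place of the chlorine of the 2-chlorophenyl ring would keep the inhibition seen with compound 2.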